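This account rests on a few compounds, and the source may have more. Where it says the series, first, only, none or still open, it means among the compounds named here.

Compound 1 `COc1cc(/C=C2\C(=O)Nc3ccccc32)ccc1OCCCN1CCN(c2ncccc2C(F)(F)F)CC1` and compound 2 `COc1cc(/C=C2\C(=O)Nc3ccc(Cl)cc32)ccc1OCCCN1CCN(c2ncccc2C(F)(F)F)CC1` share one core and differ at a single aromatic carbon. In a functional assay on DU-145 cells (Homo sapiens) for cytotoxicity, read by MTT assay, with a stated time of 48 h (on this read-out lower numbers stand for stronger inhibition and higher numbers for weaker inhibition), compound 1 reaches only the limit > 20000 nM, a limit of the assay rather than a number (the limit of > 20000 nM in this assay, at which 1 of the 2 values shown sits). In this assay, for the measured compounds named here, compound 2 gives 1610 nM, the only actual number among the two measurements, and the step of an at least 12-fold lower number from compound 1 to compound 2 (1.09 log units; beyond the scatter) is large. Compound 3 `COc1cc(/C=C2\C(=O)Nc3ccc(C)cc32)ccc1OCCCN1CCN(c2ncccc2C(F)(F)F)CC1` is compound 2 with methyl in place of chloro on an aromatic carbon. The measured step from hydrogen to chloro was large, yet it says little about swapping chloro for methyl, so only a small shift in this assay, if any, is expected. Compound 3 is expected to give about 2500 nM, between 800 nM and 8000 nM. That estimate means a step of a 1.6-fold higher number from compound 2 to compound 3 (0.19 log units; within the scatter).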

Compound 3, half-maximal inhibitory concentration: > 20000 nM
Compound 3: no number, only a limit (the forecaster's own chance of this, stated with the estimate: 10%); middle value at least 8.0-fold (0.90 log units) away from the limit.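

Replacing chloro with methyl on this aromatic carbon erases the activity that chloro brought in this assay (an at least 12-fold higher number from compound 2 to compound 3 (1.09 log units; beyond the scatter)). Both groups count one heavy atom, so that count alone does not decide the outcome here. The step from compound 1 to compound 3 cannot be read, and compound 3, like compound 1, gives a limit of the assay rather than a number: the limit of > 20000 nM in this assay, at which 2 of the 3 values shown sit.

As far as these compounds go, whether bromo or fluoro on this carbon would behave like chloro remains open. So does the outcome with methoxy or an amine there.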